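Two Methyls on the Phenyl Arm of Compound 3

The source may report more compounds than this note shows. Statements on the series, on what has been measured and on what is new or still open speak of the compounds shown alone.

Measured so far in a functional assay on HeLa cells (Homo sapiens) for inhibition, read by CCK-8 assay, with a stated time of 48 h; a lower number here means a stronger inhibitor, a higher number a weaker inhibitor:
compound 1 `COc1ccc(-c2cc3nccc(-c4cc(OC)c(OC)c(OC)c4)n3n2)cc1N` gives 283 nM
compound 2 `COc1cc(-c2ccnc3cc(-c4ccc(Cl)cc4)nn23)cc(OC)c1OC` gives 1490 nM
compound 3 `COc1cc(-c2ccnc3cc(-c4ccccc4)nn23)cc(OC)c1OC` gives 458 nM

Among these three numbers compound 3 sits second highest. Its nearest neighbour is compound 1, with a step of a 1.6-fold higher number from compound 1 to compound 3 (0.21 log units; within the scatter) between them, which is within the scatter, so the two cannot be ranked against each other. Its furthest neighbour is compound 2, and the step of a 3.3-fold lower number from compound 2 to compound 3 (0.51 log units; beyond the scatter) is beyond the scatter, a modest move in favour of compound 3.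

Compound 4 `COc1cc(-c2ccnc3cc(-c4ccc(C)c(C)c4)nn23)cc(OC)c1OC` has not yet been measured. It differs from compound 3 by 3,4-dimethylphenyl in place of phenyl on an aromatic carbon. Among the measured compounds shown here, the steps that bear on this are the two that also change the same phenyl ring: placing a chloro on it, as in a 3.3-fold lower number from compound 2 to compound 3 (0.51 log units; beyond the scatter) read backwards, gave a modestly higher number, while swapping in 3-amino-4-methoxyphenyl, as in a 1.6-fold higher number from compound 1 to compound 3 (0.21 log units; within the scatter), stayed within the scatter. On that basis a small shift toward a higher number in this assay is expected, though it may well fall within the scatter; the estimated step is a 1.5-fold higher number from compound 3 to compound 4 (0.18 log units; within the scatter). For compound 4 the expected value is 700 nM, with a range from 300 nM to 1800 nM.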

Compound 4, half-maximal inhibitory concentration: 241 nM
The estimate for compound 4 lay 2.9-fold (0.46 log units) above the measured number, and the stated range ends above it.
By their numbers in this assay, from the lowest: compounds 4, 1 and 3 (each within the scatter of the next); then compound 2.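

In this assay, among the compounds shown here, adding two methyls to the phenyl on this aromatic carbon, next to the ring nitrogen of the five-membered ring, gives no step that can be read as a change: a 1.9-fold lower number from compound 3 to compound 4 (0.28 log units; within the scatter) leaves the two compounds unranked. The earlier chloro result therefore does not mean that any addition to this ring raises the number, since the swap of 4-chlorophenyl for 3,4-dimethylphenyl gives a 6.2-fold lower number from compound 2 to compound 4 (0.79 log units; beyond the scatter), so the outcome depends on which groups the ring carries. The comparison with the amino- and methoxy-bearing arm gives a 1.2-fold lower number from compound 1 to compound 4 (0.07 log units; within the scatter), which shows that two quite different substituted rings at this position cannot be told apart in this assay.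

No measurement at hand explains why the methyl and chloro rings part ways. The compounds shown leave open whether both methyls are needed, and whether a longer chain such as ethyl or a carboxylic acid on the same ring would keep the number this low.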